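From isopropyl to 2-hydroxyethyl on the amide side chain

The source may hold more compounds than are shown below. What is called first, only, known or untested is meant among the compounds shown, and "the series" means these compounds.

In a functional assay on PC-3 cells (Homo sapiens) for antiproliferative activity, read by MTT assay, with a stated time of 24 h (on this read-out lower numbers stand for stronger inhibition and higher numbers for weaker inhibition), compound 3 (`CCn1c(C(=O)N[C@@H](CO)C(C)C)ccc1C(CC)(CC)c1ccc(OCS(=O)(=O)c2ccccc2)c(C)c1`) gives 10600 nM and holds the higher of the two actual numbers in this small series. In this assay compound 2 (`CCn1c(C(=O)NC2(CO)CC2)ccc1C(CC)(CC)c1ccc(OCS(=O)(=O)c2ccccc2)c(C)c1`) gives 3560 nM as the other number. Exchanging 1-(hydroxymethyl)cyclopropyl for 1-(hydroxymethyl)-2-methylpropyl gives a 3.0-fold higher number from compound 2 to compound 3 (0.47 log units; beyond the scatter) and this is the closest gap among the measured compounds. In this assay compound 1 (`CCn1c(C(=O)N[C@H](C)C(=O)OC)ccc1C(CC)(CC)c1ccc(OCS(=O)(=O)c2ccccc2)c(C)c1`) reads > 50000 nM and this value is a limit, not a number. Replacing its 1-(methoxycarbonyl)ethyl group with 1-(hydroxymethyl)cyclopropyl gives an at least 14-fold lower number from compound 1 to compound 2 (1.14 log units; beyond the scatter) and replacing it with 1-(hydroxymethyl)-2-methylpropyl gives an at least 4.7-fold lower number from compound 1 to compound 3 (0.67 log units; beyond the scatter) so all three measured steps show the read-out moving with the group on the amide-type nitrogen.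

Compound 4 (`CCn1c(C(=O)N[C@@H](CO)CCO)ccc1C(CC)(CC)c1ccc(OCS(=O)(=O)c2ccccc2)c(C)c1`) departs from compound 3 by 2-hydroxyethyl in place of isopropyl on a saturated chain carbon bound to an amide-type nitrogen and a saturated chain carbon in a change that puts 2-hydroxyethyl in place of isopropyl on a saturated chain carbon bound to an amide-type nitrogen and a saturated chain carbon. Going by the values given here, no measured step makes this exact exchange. The best guide to size is a 3.0-fold higher number from compound 2 to compound 3 (0.47 log units; beyond the scatter) and it suggests a modest shift at most, with a slightly higher number expected and no change beyond the scatter also possible. The expected step is a 1.4-fold higher number from compound 3 to compound 4 (0.15 log units; within the scatter) as an estimate only. In this assay compound 4 is expected at 15000 nM with an estimated range from 5000 nM to 50000 nM for the coming measurement.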

Compound 4, half-maximal inhibitory concentration: 14100 nM
Beside the measured number, compound 4's estimate is 1.1-fold (0.03 log units) above it; the range from low to high includes it.
By their numbers in this assay, from the lowest: compound 2; then compounds 3 and 4 (each within the scatter of the next). At a limit, above all of these: compound 1.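

In this assay the exchange of isopropyl for 2-hydroxyethyl on a saturated chain carbon bound to an amide-type nitrogen and a saturated chain carbon gives a 1.3-fold higher number from compound 3 to compound 4 (0.12 log units; within the scatter) even though the two groups differ in their counted hydrogen-bond donors and acceptors, so this read-out does not separate them at this position. The 1-(hydroxymethyl)cyclopropyl group of compound 2 still reads apart from both open chains, with a 3.0-fold higher number from compound 2 to compound 3 (0.47 log units; beyond the scatter) and with a 4.0-fold higher number from compound 2 to compound 4 (0.60 log units; beyond the scatter) in the same direction. Compound 1 stands at a limit and not a number, so an at least 3.5-fold lower number from compound 1 to compound 4 (0.54 log units; beyond the scatter) is only a bound: the limit of > 50000 nM in this assay, at which 1 of the 4 values shown sits.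

On these data alone, whether an amine, a carboxylic acid or a longer chain bearing a hydroxyl in place of 2-hydroxyethyl would read apart from compound 3 and compound 4 stays open. Compound 2 is also the only one shown with a ring on this amide-type nitrogen, so one compound alone cannot tell whether other small rings would read the same way.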